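Chloro in Place of Fluoro: A Step Without a Measurement

The compounds below may be only part of what the source reports. "The series", "measured", "known", "first", "only" and "open" are said of these compounds alone.

compound 1 `Cc1ccccc1-c1cccc(COc2ccc(S(=O)(=O)CC(=O)O)cc2)c1` gives 2.35
compound 2 `O=C(O)CS(=O)(=O)c1ccc(OCc2cccc(-c3ccccc3F)c2)cc1` gives "not determined" (no result reported)

In a physicochemical assay for lipophilicity, using the shake flask method, in phosphate buffer, measured as octanol-water partition, with a stated time of 24 h, at pH 7.4, tested at 100 uM (on this read-out higher numbers stand for higher lipophilicity and lower numbers for lower lipophilicity), only compound 1 carries a number. Compound 2 stands without a single value, so it offers no measured starting point for the step that follows. The next compound, compound 3 `O=C(O)CS(=O)(=O)c1ccc(OCc2cccc(-c3ccccc3Cl)c2)cc1` is still to be measured. A single change makes the step chloro in place of fluoro on an aromatic carbon with chloro in place of fluoro on an aromatic carbon, ortho to a large group. The same difference can be read as 2-fluorophenyl to 2-chlorophenyl. Among the compounds with values here, no measured pair here shows this change, so its size in this assay can only be expected: a small rise, around the usual scatter or slightly beyond it. Within the data shown here, the sole anchor is compound 1 at 2.35 and compound 3 is expected to fall near it. For compound 3 the estimated distribution coefficient is 2.45 (expected range 2.05 to 2.85).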

Compound 3, distribution coefficient: 2.47
The estimate for compound 3 lay 0.02 log units below the measured number; the measured number falls inside the stated range.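

In this assay, swapping methyl for chloro gives a number 0.12 log units higher from compound 1 to compound 3 (within the scatter), so this place now carries two measured groups, and the values for methyl and chloro lie within the usual scatter of each other. Compound 3 also gives the 2-chlorophenyl series its first number, which compound 2 could not give for 2-fluorophenyl, and the step of chloro in place of fluoro cannot be read. No measured finding is available to explain why methyl and chloro lie so close together.

As far as these compounds go, how compound 2, with its fluoro group, stands against compound 1 and compound 3 remains open. Also open, from the compounds shown here alone, is whether an amine or a methoxy group on the same aromatic carbon would stay within the scatter of compound 3 or move clearly away from it.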